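Chain lengthening at two ends of a shared-core series

A few compounds are considered here, and "the series" means these few. Any claim that something is new, unique, unknown or untested is made for them only; others in the source may bear on it.

Compound 1 `CCc1ccccc1OCC(O)COc1ccc2c(O)c([N+](=O)[O-])c(=O)oc2c1` and compound 2 `CCCc1ccccc1OCC(O)COc1ccc2c(O)c([N+](=O)[O-])c(=O)oc2c1` share one core; compound 3 `CCCc1c(OCC(O)COc2ccc3c(O)c([N+](=O)[O-])c(=O)oc3c2CC)ccc(C(C)=O)c1O` and compound 4 `CCCc1c(OCC(O)COc2ccc3c(O)c([N+](=O)[O-])c(=O)oc3c2CCC)ccc(C(C)=O)c1O` share another, and the difference between the two cores is not broken down here. In a functional assay on ileum (Cavia porcellus) for antagonist activity (on this read-out lower numbers stand for stronger inhibition and higher numbers for weaker inhibition), compound 1 gives 2700 nM and compound 2 gives 110 nM. The change methyl in place of hydrogen on a saturated chain carbon, two bonds along the chain from an aromatic carbon produced a 25-fold lower number from compound 1 to compound 2 (1.39 log units; beyond the scatter). In this assay compound 3 gives 50 nM, the lowest of the three numbers. Compound 4 carries the same change, (methyl in place of hydrogen on a saturated chain carbon, two bonds along the chain from an aromatic carbon), on the other core. The step of a 2.0-fold lower number from compound 3 to compound 4 (0.30 log units; within the scatter) is expected to be smaller than the earlier one because a single case a 25-fold lower number from compound 1 to compound 2 (1.39 log units; beyond the scatter) supports this direction and it sits on a different core. Compound 4 is thus estimated at 25 nM in this assay, with 8 nM to 100 nM as the expected range.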

Compound 4, half-maximal inhibitory concentration: 200 nM
For compound 4 the middle estimate is 8.0-fold (0.90 log units) below the measured one; the whole stated range lies below it.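

In this assay, methyl in place of hydrogen on a saturated chain carbon, two bonds along the chain from an aromatic carbon, gives a 4.0-fold higher number from compound 3 to compound 4 (0.60 log units; beyond the scatter), and the two cores do not respond alike: the same change on two cores in this assay, a 25-fold lower number (1.39 log units; beyond the scatter) from compound 1 to compound 2 and a 4.0-fold higher number (0.60 log units; beyond the scatter) from compound 3 to compound 4, 98-fold (1.99 log units) apart, beyond the scatter of two such steps. In this series, the effect of this ethyl to propyl change therefore does not carry over from the core of compound 1 to the core of compound 3, in either size or direction. With one pair on each core, these data do not show which part of the difference between the cores accounts for this, or how the change would behave on a further core.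

Still open, from the compounds shown here alone, is how a butyl chain at the same place would compare on either core. Also open, going by these compounds, is whether a chain ending in an amine would separate the two cores in the same way.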